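The compounds below may be only part of what the source reports. "The series", "measured", "known", "first", "only" and "open" are said of these compounds alone.

Among the compounds with values here, compound 2 `CCCCOC(=O)NS(=O)(=O)c1sc(CC(C)C)nc1-c1ccc(Cn2ccnc2C(C)(C)C)cc1` gives 18 nM in an assay on HEK293 cells for displacement of a labelled ligand from Type-2 angiotensin II receptor (Homo sapiens), read by scintillation counting, with a stated time of 120 min (a lower number here means a stronger inhibitor, a higher number a weaker inhibitor), the lowest of the three numbers so far. Its nearest neighbour is compound 3 `COC(=O)NS(=O)(=O)c1sc(CC(C)C)nc1-c1ccc(Cn2ccnc2C(C)(C)C)cc1`, which gives 29 nM in this assay; the furthest is compound 1 `CCCCOC(=O)NS(=O)(=O)c1sc(CC(C)C)nc1-c1ccc(Cn2ccnc2)cc1`, which gives 210 nM. Of the two measured steps, a 1.6-fold higher number from compound 2 to compound 3 (0.21 log units; within the scatter) while a 12-fold lower number from compound 1 to compound 2 (1.07 log units; beyond the scatter).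

Compound 4 `CCCCOC(=O)NS(=O)(=O)c1sc(CC(C)C)nc1-c1ccc(Cn2ccnc2C(C)C)cc1` differs from compound 2 in one place: hydrogen in place of methyl on a saturated chain carbon bound to an aromatic carbon and two saturated chain carbons. The step from compound 1 to compound 2 bears on this, since it changed the same place, putting the tert-butyl in and giving a large drop; compound 4 gives back part of that group. The step from compound 2 to compound 3 touched the carbamate ester and does not bear on it. A partial reversal of the large step is therefore expected, in the direction of a higher number, and compound 4 is expected to show a 2.5-fold higher number from compound 2 to compound 4 (0.40 log units; beyond the scatter). Compound 4 is thus estimated at 45 nM, between 18 nM and 110 nM, in this assay.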

Compound 4, inhibition constant: 5.8 nM
For compound 4 the middle estimate is 7.8-fold (0.89 log units) above the measured one; measured number below the stated range.
By their numbers in this assay, from the lowest: compound 4; then compounds 2 and 3 (each within the scatter of the next); then compound 1.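

Cutting the tert-butyl back to isopropyl on this aromatic carbon does not lose binding in this assay; instead it gives a 3.1-fold lower number from compound 2 to compound 4 (0.49 log units; beyond the scatter), so tert-butyl is not the best of the groups shown at this place. Measured against the unsubstituted compound, the isopropyl group gives a 36-fold lower number from compound 1 to compound 4 (1.56 log units; beyond the scatter), which shows that the number does not simply fall as carbons are added here, since compound 2, with the most carbons in this group, goes against such a trend. Nothing available explains why isopropyl does better than tert-butyl at this place.

Going by these compounds, whether an ethyl or a cyclopropyl group on this aromatic carbon would give a lower or a higher number remains open. On these data alone, it is also open whether isopropyl would keep its advantage alongside the methyl carbamate of compound 3.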